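Methyl in place of hydrogen on the carboxy analogue

This account rests on a few compounds, and the source may have more. Where it says the series, first, only, none or still open, it means among the compounds named here.

Measured compounds:
- Compound 1, `Cc1ccc2nc(C(=O)Nc3c(F)cc(-c4cccc(F)c4)cc3F)c(C)c(O)c2c1`: in a functional assay on Hep 3B2 cells (Homo sapiens) for antiproliferative activity, read by MTT assay, with a stated time of 24 h, tested at 0.01 ug/mL (a lower number here means a weaker effect, a higher number a stronger effect of the compound at the concentration tested), compound 1 gives 0.22%.
- Compound 2, `CCc1ccc2nc(C(=O)Nc3c(F)cc(-c4cccc(F)c4)cc3F)c(C)c(O)c2c1`: in this assay compound 2 gives 0.74%.
- Compound 3, `Cc1ccc2nc(C(=O)Nc3c(F)cc(-c4cccc(F)c4)cc3F)c(C)c(C(=O)O)c2c1`: in this assay compound 3 gives 0.36%.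

Compound 3 stands second highest of the three numbers in this assay. Its nearest neighbour is compound 1, a number 0.1 percentage points higher from compound 1 to compound 3 (within the scatter); its furthest is compound 2, and the two values of compound 3 and compound 2 sit within the scatter of each other. For the measured compounds named here, all three numbers are close to zero at the concentration tested, and no pair is separated beyond the scatter.

Compound 4, `CCc1ccc2nc(C(=O)Nc3c(F)cc(-c4cccc(F)c4)cc3F)c(C)c(C(=O)O)c2c1`, is not yet measured in this assay. It differs from compound 3 by methyl in place of hydrogen on a saturated chain carbon bound to an aromatic carbon. Going by the values given here, the one measured step with the same change is a number 0.5 percentage points higher from compound 1 to compound 2 (within the scatter), made on the hydroxy analogue. The change of hydroxy to carboxy itself gave a number 0.1 percentage points higher from compound 1 to compound 3 (within the scatter). Nothing here points to a step beyond the scatter, so the step in this assay is expected to be a number 0.3 percentage points higher from compound 3 to compound 4 (within the scatter). Compound 4 is therefore expected to give 0.7%, within -5% to 7%.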

Compound 4, a percentage reported as inhibition, at one concentration (the size of the read-out at that concentration, not a potency): -0.25%
Estimate against measurement, compound 4: 1 percentage points above, within the range that was stated.
By their numbers in this assay, from the lowest: compounds 4, 1, 3 and 2 (each within the scatter of the next).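

In this assay, methyl in place of hydrogen on a saturated chain carbon bound to an aromatic carbon now has a second reading, on the carboxy analogue, a number 0.6 percentage points lower from compound 3 to compound 4 (within the scatter), and the two readings cannot be told apart: the same change on two cores in this assay, a number 0.5 percentage points higher (within the scatter) from compound 1 to compound 2 and a number 0.6 percentage points lower (within the scatter) from compound 3 to compound 4, 1.1 percentage points apart, within the scatter of two such steps. Carboxy in place of hydroxy on an aromatic carbon also has a second reading, on the ethyl analogue, a number 1 percentage points lower from compound 2 to compound 4 (within the scatter), again with no separation between the two cores: the same change on two cores in this assay, a number 0.1 percentage points higher (within the scatter) from compound 1 to compound 3 and a number 1 percentage points lower (within the scatter) from compound 2 to compound 4, 1.1 percentage points apart, within the scatter of two such steps. Neither change therefore shows any dependence on the other in this assay, and no step among these compounds leaves the scatter.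

Going by these compounds, it remains open whether a longer chain such as propyl at this position, or an amine in place of the carboxy group, would give a step beyond the scatter. All readings come from a single concentration and give only the size of the effect there, so whether any of these compounds has a stronger or weaker effect at other concentrations also remains open.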